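A few compounds are considered here, and "the series" means these few. Any claim that something is new, unique, unknown or untested is made for them only; others in the source may bear on it.

Measured in an ADME assay on a cell-free system (plasma, Homo sapiens) for metabolic stability, read by HPLC; a higher number here means that the compound lasts longer, a lower number that the compound disappears faster:
- compound 1 `CCCC(CCC)C(=O)N(C)/N=N/c1ccc(C(=O)OCC)cc1`: > 40 h
- compound 2 `CCCC(CCC)C(=O)N(C)/N=N/c1ccc(C(=O)OC)cc1`: > 40 h

Both entries are limits of the assay and not numbers. Compound 2 therefore has only a limit, > 40 h. Among the compounds with values here, the whole series so far comes down to the limit of > 40 h in this assay, at which 2 of the 2 values shown sit, so no true value is yet available as a reference point.

The next compound is compound 3 `CCCC(CCC)C(=O)N(C)/N=N/c1ccc(Br)cc1`, which carries bromo in place of methoxycarbonyl on an aromatic carbon, para to a large group: bromo in place of methoxycarbonyl on an aromatic carbon.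

Within the data shown here, the only measured step, a step that the two limits leave unreadable from compound 1 to compound 2, changes the group that now leaves, but it gives no size to carry over. Among the measured compounds shown here, no measured step covers the replacement of that group by bromo.

With so little to go on, no step beyond the scatter is expected in this assay, and no direction can be assigned. This expectation rests on compound 2 with its limit of > 40 h, and it remains a weak one. The estimated step is a step that the limit leaves unreadable from compound 2 to compound 3. A reading that is again only a limit is considered more likely than not.

The expected value for compound 3 is 45 h, with an estimated range of 15 h to 100 h.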

Compound 3, half-life: > 40 h
Compound 3 ended at the assay's limit; the forecaster's own chance of this, stated with the estimate: 60%; the middle value does not contradict the limit.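

In this assay, within the data shown here, compound 3 gives > 40 h, a limit of the assay and not a number, so no step between compound 3 and compound 1 or compound 2 can be read. The compounds shown leave open whether bromo, methoxycarbonyl and ethoxycarbonyl differ at all in half-life, as the whole series rests on one limit: the limit of > 40 h in this assay, at which 3 of the 3 values shown sit.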